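The compounds below may be only part of what the source reports. "The series", "measured", "known", "first", "only" and "open" are said of these compounds alone.

Three compounds share one core and differ only in the group carried on the amide-type nitrogen. Compound 1 `CC(=O)Oc1ccc(-c2ccc(F)cc2F)cc1C(=O)NCc1ccccc1` carries a benzyl group there, and in a functional assay on the whole organism (Ear) for inhibition, with Mus musculus as the target, at a dose of 40 mg/kg by the oral route (a lower number here means less inhibition, a higher number more inhibition at the dose given (going by the name of the read-out)), compound 1 gives 34.1%. Compound 2 `CC(=O)Oc1ccc(-c2ccc(F)cc2F)cc1C(=O)Nc1cccc(C)c1` carries a 3-methylphenyl group, and compound 2 gives 12.8%. Compound 3 `CC(=O)Oc1ccc(-c2ccc(F)cc2F)cc1C(=O)Nc1ccc(C)cc1` carries a 4-methylphenyl group, and compound 3 gives 36.4%, the highest of the three numbers, though compound 1 lies within the scatter of it, while compound 2 stands beyond the scatter below it.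

The measured steps are a number 2.3 percentage points higher from compound 1 to compound 3 (within the scatter), a number 21.3 percentage points lower from compound 1 to compound 2 (beyond the scatter) and a number 23.6 percentage points higher from compound 2 to compound 3 (beyond the scatter). Compound 4 `CC(=O)Oc1ccc(-c2ccc(F)cc2F)cc1C(=O)NN1CCOCC1` is the next step from compound 3: morpholin-4-yl in place of 4-methylphenyl on an amide-type nitrogen. All three measured steps exchange the group on the same amide-type nitrogen, so they bear on this change, but each of them keeps a six-membered aromatic ring of carbon only, whereas here a six-membered non-aromatic ring with 2 hetero atoms enters. Those steps show that exchanging one group on this nitrogen for another can move the number beyond the scatter in either direction. Within the data shown here, no measured compound carries anything like morpholin-4-yl, so the direction is uncertain, and a modest downward step is expected: a number 16.4 percentage points lower from compound 3 to compound 4 (beyond the scatter). Compound 4 is expected to give 20%, with a range from 0% to 40%.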

Compound 4, a percentage reported as inhibition, in the whole organism at one dose (the size of the read-out at that dose, not a potency): 0%
Compound 4: middle estimate off by 20 percentage points, on the high side, within the range that was stated.
By their numbers in this assay, from the lowest: compound 4; then compound 2; then compounds 1 and 3 (each within the scatter of the next).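

In this assay, among these compounds, the exchange for morpholin-4-yl on the amide-type nitrogen gives a number 36.4 percentage points lower from compound 3 to compound 4 (beyond the scatter) and a number 34.1 percentage points lower from compound 1 to compound 4 (beyond the scatter) and, even from the lowest of the earlier compounds, a number 12.8 percentage points lower from compound 2 to compound 4 (beyond the scatter) as well. The earlier compounds shown here showed the number moving in either direction among groups with a six-membered aromatic ring of carbon only; with a six-membered non-aromatic ring with 2 hetero atoms in place, compound 4 falls beyond the scatter below all three, so this position also has a much lower end. The change removes the aromatic ring and brings in 2 hydrogen-bond acceptors at once, and nothing available here explains the fall or ties it to either difference.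

As far as these compounds go, whether the fall follows the loss of the aromatic ring or the arrival of the hetero atoms stays open: a cyclohexyl group, of carbon only, or piperidin-1-yl, without the ring oxygen, would bear on that. Also open, from the compounds shown here alone, is how a 2-(morpholin-4-yl)ethyl group on this nitrogen would read, with the same ring carried on a two-carbon chain.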